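Swapping Phenyl for Dichlorophenyl on a Hydrazone Core

The source may report more compounds than this note shows. Statements on the series, on what has been measured and on what is new or still open speak of the compounds shown alone.

Measured compounds:
Compound 1 `CC1CCC(=NNc2ccccc2)c2ncc(C(=O)O)c(=O)n21`: 1.2 umol/kg
Compound 2 `Cc1cc(C)c(NN=C2CCC(C)n3c2ncc(C(=O)O)c3=O)c(C)c1`: 320 umol/kg

In a functional assay on the whole organism with Rattus norvegicus as the target (on this read-out lower numbers stand for an effect already at smaller amounts and higher numbers for an effect only at larger amounts of compound), compound 1 stands lowest of the two numbers, and compound 2 sits far above it, beyond the scatter. Compound 3 `CC1CCC(=NNc2ccc(Cl)c(Cl)c2)c2ncc(C(=O)O)c(=O)n21` is the next candidate; it differs from compound 1 by 3,4-dichlorophenyl in place of phenyl on an amine nitrogen. For the measured compounds named here, no measured pair shows a step of exactly this kind, so the outcome is uncertain. A small rise is expected for compound 3, a 2.5-fold higher number from compound 1 to compound 3 (0.40 log units; beyond the scatter), though a change within the scatter is also plausible. Compound 3 is estimated at 3 umol/kg, with a range from 0.8 umol/kg to 15 umol/kg.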

Compound 3, dose for 50% inhibition: > 100 umol/kg
Compound 3: a limit, no number; the forecaster's own chance of this, stated with the estimate: 5%; at least 33-fold (1.52 log units) between middle value and limit.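

In this assay, compound 3 gives > 100 umol/kg, which is a limit and not a number. Putting 3,4-dichlorophenyl in place of phenyl on an amine nitrogen brings an at least 83-fold higher number from compound 1 to compound 3 (1.92 log units; beyond the scatter), so this position is sensitive: adding two chlorine atoms to the ring is enough for a large step. The true size of that step stays unknown, as it rests on a limit: the limit of > 100 umol/kg in this assay, at which 1 of the 3 values shown sits.

On these data alone, whether a single fluorine or a methoxy group on the phenyl ring would keep the low number of compound 1 remains open. The compounds shown give no cause for the step.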